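Hydroxymethyl step from compound 3 to compound 4

This account rests on a few compounds, and the source may have more. Where it says the series, first, only, none or still open, it means among the compounds named here.

compound 1 `O=C(NCc1ccccn1)c1ncc([N+](=O)[O-])[nH]1`: > 100000 nM (limit)
compound 2 `NC(=O)c1ncc([N+](=O)[O-])[nH]1`: > 100000 nM (limit)
compound 3 `CNC(=O)c1ncc([N+](=O)[O-])[nH]1`: > 100000 nM (limit)

In a toxicity assay on HepG2 cells (Homo sapiens) for inhibition, read by resazurin assay, with a stated time of 24 h (a lower number here means that less compound is tolerated, a higher number that more compound is tolerated), compound 3 gives > 100000 nM and this entry is a limit, not a number. Its neighbours offer no number to place it against, as the limit of > 100000 nM in this assay, at which 3 of the 3 values shown sit, shows for the whole set.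

Compound 4 `O=C(NCCO)c1ncc([N+](=O)[O-])[nH]1` carries hydroxymethyl in place of hydrogen on a saturated chain carbon bound to an amide-type nitrogen and the rest of the structure stays as in compound 3.

The closest measured change at this place is a step that the two limits leave unreadable from compound 1 to compound 3 and the other one nearby is a step that the two limits leave unreadable from compound 2 to compound 3 so neither gives a size to carry over. The expectation rests mainly on compound 1, which holds > 100000 nM as a limit with pyridin-2-yl on that same carbon. Hydroxymethyl is a smaller entering group than that one, and no change beyond the scatter is expected in this assay here. The estimated step is a number no higher from compound 3 to compound 4 (the limit leaves the size open) and another report as a limit is the likeliest outcome. For compound 4 the estimated value is 100000 nM with an expected range from 50000 nM to 200000 nM as the working figure.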

Compound 4, half-maximal cytotoxic concentration: > 100000 nM
Compound 4 ended at the assay's limit (the forecaster's own chance of this, stated with the estimate: 90%); the middle value lies on the limit itself.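

In this assay compound 4 gives > 100000 nM, which is a limit and not a number. No new step can be read between compound 4 and compounds 1, 2 or 3, as all four stand at the same limit: the limit of > 100000 nM in this assay, at which 4 of the 4 values shown sit.

The compounds shown leave open whether the groups on the amide-type nitrogen differ at all in this assay.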